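This account rests on a few compounds, and the source may have more. Where it says the series, first, only, none or still open, it means among the compounds named here.

Measured compounds:
compound 1 `COc1ccc(OC)c(/C=C/c2nnc(Nc3ccc(Cl)cc3)o2)c1` — > 100000 nM
compound 2 `COc1ccc(OC)c(/C=C/C(=O)N/N=C/c2ccc(Cl)cc2)c1` — > 100000 nM

Of the compounds shown here, two have been tested in a functional assay on K562 cells (Homo sapiens) for antiproliferative activity, read by sulforhodamine B assay, with a stated time of 48 h; on this read-out lower numbers stand for stronger inhibition of growth and higher numbers for weaker inhibition of growth. In this assay compound 1 gives only a limit, > 100000 nM. Compound 2 likewise gives only a limit, > 100000 nM. Among the compounds with values here, compound 2 thus sits at the limit of > 100000 nM in this assay, at which 2 of the 2 values shown sit, so it has no number of its own, and no step between measured compounds can be stated; the account can only say that neither value is a number.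

Compound 3 `COc1ccc(OC)c(/C=C/C(=O)N/N=C/c2ccccc2)c1` differs from compound 2 by hydrogen in place of chloro on an aromatic carbon, the chloro having sat para to a large group, the same difference read one bond further out being 4-chlorophenyl to phenyl. With compound 2 at the limit of > 100000 nM in this assay, at which 2 of the 2 values shown sit, the measurements give no direction for this change, and the step from compound 2 to compound 3 is expected to be none beyond the scatter, namely a step that the limit leaves unreadable from compound 2 to compound 3. Compound 3 is therefore estimated at 150000 nM, with a range from 50000 nM to 500000 nM, and is most probably reported again only as a limit.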

Compound 3, concentration for total growth inhibition: > 100000 nM
Compound 3: only a limit was reported (the forecaster's own chance of this, stated with the estimate: 85%); the middle value does not contradict the limit.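

Compound 2 and compound 3 are both reported only as limits in this assay, so no step can be read for hydrogen in place of chloro: the limit of > 100000 nM in this assay, at which 3 of the 3 values shown sit.

The compounds shown leave open whether chloro or hydrogen at this place makes any difference to growth inhibition, as none of them has a value that is a number.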